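Pyridin-4-yl in Place of Phenyl: Expected Cytotoxicity

The compounds below may be only part of what the source reports. "The series", "measured", "known", "first", "only" and "open" are said of these compounds alone.

The compounds are compared in an ADME assay on MT4 cells (Homo sapiens) for cytotoxicity, read by MTT assay; on this read-out lower numbers stand for higher toxicity in this test and higher numbers for lower toxicity in this test. Compound 1 `Cc1ccc(NC(=S)OCCc2ccccn2)cc1` gives 75000 nM in this assay. Compound 2 `Cc1ccc(NC(=S)OCCc2ccccc2)cc1` reaches only a limit of this assay, > 100000 nM, so for compound 2 a bound and no number is known (the limit of > 100000 nM in this assay, at which 1 of the 3 values shown sits). Compound 3 `COc1ccc(NC(=S)OCCc2ccccc2)cc1` gives 36000 nM. The step of an at least 1.3-fold higher number from compound 1 to compound 2 (0.12 log units; that floor lies within the scatter) has a floor inside the scatter, whereas the step of an at least 2.7-fold lower number from compound 2 to compound 3 (0.44 log units; beyond the scatter) lies beyond it.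

Compound 4 `Cc1ccc(NC(=S)OCCc2ccncc2)cc1` differs from compound 2 by pyridin-4-yl in place of phenyl on a saturated chain carbon, two bonds along the chain from an oxygen on an unsaturated carbon. Of the measured steps only an at least 1.3-fold higher number from compound 1 to compound 2 (0.12 log units; that floor lies within the scatter) bears on this change, since it also exchanges phenyl for a pyridine ring at the same place, there as pyridin-2-yl; its floor lies within the scatter, and pyridin-4-yl itself has not been tested. For compound 4 the expected step is an at least 1.1-fold lower number from compound 2 to compound 4 (0.07 log units; that floor lies within the scatter), which is not expected to go beyond the scatter. Compound 4 is estimated at 85000 nM, within a range from 35000 nM to 200000 nM.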

Compound 4, half-maximal cytotoxic concentration: > 100000 nM
Compound 4: only a limit was reported; the forecaster's own chance of this, stated with the estimate: 45%; at least 1.1-fold (0.07 log units) between middle value and limit.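

In this assay compound 4 gives > 100000 nM, which is a limit and not a number. Going by these compounds alone, compound 2 and compound 4 thus stop at the same limit, so the exchange of phenyl for pyridin-4-yl at this place cannot be read as a step, and it shows only that a ring with one hetero atom can reach this limit here: the limit of > 100000 nM in this assay, at which 2 of the 4 values shown sit. Moving from pyridin-2-yl to pyridin-4-yl gives an at least 1.3-fold higher number from compound 1 to compound 4 (0.12 log units; that floor lies within the scatter), and since that floor lies within the scatter, the data do not separate the two pyridine rings.

From the compounds shown here alone, what remains open is whether phenyl and pyridin-4-yl differ at all beyond the limit of this test. Going by these compounds, it is also open whether pyridin-3-yl, a longer chain or an amine at this place would stay at the limit, and whether methoxy in place of methyl on the pyridin-4-yl compound would lower the number as it does from compound 2 to compound 3.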